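The source may report more compounds than this note shows. Statements on the series, on what has been measured and on what is new or still open speak of the compounds shown alone.

Compound 1 `ClCc1ccc(Cn2cnc3c(Cl)ncnc32)cc1` and compound 3 `ClCc1ccc(Cn2cnc3c(Cl)nc(Cl)nc32)cc1` differ by chloro in place of hydrogen on an aromatic carbon. In a functional assay on SK-MEL-28 cells (Homo sapiens) for cytotoxicity, read by sulforhodamine B assay, with a stated time of 48 h (on this read-out lower numbers stand for higher toxicity in this test and higher numbers for lower toxicity in this test), compound 1 gives only a limit, > 100000 nM. Compound 3 gives 46800 nM in this assay. The step of an at least 2.1-fold lower number from compound 1 to compound 3 (0.32 log units; beyond the scatter) rests on (the limit of > 100000 nM in this assay, at which 1 of the 3 values shown sits), so its full size is not known. Compound 2 `ClCc1cccc(Cn2cnc3ncnc(Cl)c32)c1` gives 42700 nM in this assay; the difference between the core of compound 2 and the core of compound 1 is not broken down here. Compound 4 `ClCc1cccc(Cn2cnc3nc(Cl)nc(Cl)c32)c1` differs from compound 2 by chloro in place of hydrogen on an aromatic carbon, the same change as before. For compound 4 a step of a 2.1-fold lower number from compound 2 to compound 4 (0.33 log units; beyond the scatter) is expected, set beside the earlier step of an at least 2.1-fold lower number from compound 1 to compound 3 (0.32 log units; beyond the scatter), which is known only as a lower bound through (the limit of > 100000 nM in this assay, at which 1 of the 3 values shown sits). Compound 4 is therefore estimated at 20000 nM in this assay, with a range from 7000 nM to 50000 nM.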

Compound 4, concentration lethal to 50% of the cells: 970 nM
The estimate for compound 4 lay 21-fold (1.31 log units) above the measured number; the measured number lies below the stated range.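

In this assay, the added chloro brings a 44-fold lower number from compound 2 to compound 4 (1.64 log units; beyond the scatter), a large step. The same change also lowers the number on the core of compound 1, so the direction carries across the two cores, but the comparison of sizes stays unsettled: the same change on two cores in this assay, an at least 2.1-fold lower number (0.32 log units; beyond the scatter) from compound 1 to compound 3 and a 44-fold lower number (1.64 log units; beyond the scatter) from compound 2 to compound 4; the limit leaves it open whether they differ. The data therefore do not show that the size of the step carries from one core to the other, and compound 1 gives only a limit: the limit of > 100000 nM in this assay, at which 1 of the 4 values shown sits.

The compounds shown leave open whether an amine or a methoxy group on the aromatic carbon between two ring nitrogen atoms would move the number as chloro does. They also leave open whether the step would hold on a third core.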